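Changing the Group on the Sulfonamide Nitrogen

The source may report more compounds than this note shows. Statements on the series, on what has been measured and on what is new or still open speak of the compounds shown alone.

Of the compounds shown here, three sharing one core have been measured in a functional assay on HT-29 cells (Homo sapiens) for antiproliferative activity, read by sulforhodamine B assay, with a stated time of 48 h; on this read-out higher numbers stand for weaker inhibition and lower numbers for stronger inhibition. Compound 1 `Cc1cccc(NS(=O)(=O)c2ccc(N3CCNC3=O)cc2)c1` gives 110 nM. Compound 2 `Cc1ccc(NS(=O)(=O)c2ccc(N3CCNC3=O)cc2)cc1C` gives 230 nM. Compound 3 `O=C1NCCN1c1ccc(S(=O)(=O)Nc2cccc(Br)c2)cc1` gives 77 nM, the lowest of the three numbers; its gap to compound 1 lies within the scatter, so these two cannot be ranked against each other, while against compound 2 the gap is a 3.0-fold lower number from compound 2 to compound 3 (0.48 log units; beyond the scatter). A methyl in place of hydrogen on an aromatic carbon gave a 2.1-fold higher number from compound 1 to compound 2 (0.32 log units; beyond the scatter), and bromo in place of methyl on an aromatic carbon gave a 1.4-fold lower number from compound 1 to compound 3 (0.15 log units; within the scatter).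

Compound 4 `Cc1ccccc1NS(=O)(=O)c1ccc(N2CCNC2=O)cc1` has not yet been measured in this assay. Its difference from compound 3 is 2-methylphenyl in place of 3-bromophenyl on a sulfonamide nitrogen. The step from compound 1 to compound 3 is the closest guide: exchanging bromo and methyl on that ring changed little. Within the data shown here, compound 1 and compound 4 each carry a single methyl on that ring, but as different groups, and no measured pair shows what that makes; the step from compound 1 to compound 2 only shows that a further methyl raised the number modestly. Compound 4 is therefore expected to sit close to compound 3, the estimated step being a 1.6-fold higher number from compound 3 to compound 4 (0.19 log units; within the scatter). Compound 4 is estimated at 120 nM in this assay, within 50 nM to 300 nM.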

Compound 4, half-maximal inhibitory concentration: 200 nM
Compound 4: the middle estimate sits 1.7-fold (0.22 log units) below what was measured; the measured number falls inside the stated range.
By their numbers in this assay, from the lowest: compounds 3, 1, 4 and 2 (each within the scatter of the next, the first and the last beyond it).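

Swapping 3-bromophenyl for 2-methylphenyl on the sulfonamide nitrogen gives a 2.6-fold higher number from compound 3 to compound 4 (0.41 log units; beyond the scatter), so this position does respond to a change of aryl group, which the bromo-for-methyl step between compound 1 and compound 3 could not show. The neighbouring comparisons stay unresolved: moving the single methyl gives a 1.8-fold higher number from compound 1 to compound 4 (0.26 log units; within the scatter), and replacing 3,4-dimethylphenyl with 2-methylphenyl gives a 1.2-fold lower number from compound 2 to compound 4 (0.06 log units; within the scatter), so compound 4 cannot be ranked against either compound 1 or compound 2, and only its gap to compound 3 can be read. No measurement available here accounts for the size of any of these steps.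

The step from compound 3 to compound 4 alters both the substituent and its place on the ring, so the two contributions cannot be separated, and a 2-bromophenyl group on the same nitrogen would be the direct test of that. The compounds shown also leave open how this position would respond to a ring carrying an amine or a carboxylic acid, or to a longer chain in place of the aryl ring.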